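Taking one methyl from compound 3

This account rests on a few compounds, and the source may have more. Where it says the series, first, only, none or still open, it means among the compounds named here.

compound 1 `Cc1ccc(NS(=O)(=O)c2ccc(N3CCNC3=O)cc2)cc1`: 260 nM
compound 2 `O=C1NCCN1c1ccc(S(=O)(=O)Nc2ccc(Cl)cc2)cc1`: 90 nM
compound 3 `Cc1cccc(NS(=O)(=O)c2ccc(N3CCNC3=O)cc2)c1C`: 110 nM

These values come from a functional assay on M21 cells (Homo sapiens) for antiproliferative activity, read by sulforhodamine B assay, with a stated time of 48 h; on this read-out lower numbers stand for stronger inhibition and higher numbers for weaker inhibition. Compound 3 at 110 nM cannot be separated from compound 2, since the data show a 1.2-fold higher number from compound 2 to compound 3 (0.09 log units; within the scatter). Compound 1 stands apart, with a 2.4-fold lower number from compound 1 to compound 3 (0.37 log units; beyond the scatter) on the way to compound 3.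

The next compound is compound 4 `Cc1ccccc1NS(=O)(=O)c1ccc(N2CCNC2=O)cc1`. The change is hydrogen in place of methyl on an aromatic carbon, so that 2,3-dimethylphenyl becomes 2-methylphenyl.

Going by the values given here, no measured step removes a methyl on its own. The closest evidence is a 2.4-fold lower number from compound 1 to compound 3 (0.37 log units; beyond the scatter), where 2,3-dimethylphenyl replaces 4-methylphenyl. The swap of chloro for methyl gives a 2.9-fold lower number from compound 1 to compound 2 (0.46 log units; beyond the scatter) and is also modest. Both suggest that a single change on this ring moves the number only modestly, so a small move toward a higher number is expected in this assay. The expected change is a 1.5-fold higher number from compound 3 to compound 4 (0.19 log units; within the scatter) and may not clear the scatter. For compound 4 the estimated value is 170 nM, with an expected range from 70 nM to 400 nM.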

Compound 4, half-maximal inhibitory concentration: 150 nM
The estimate for compound 4 lay 1.1-fold (0.05 log units) above the measured number; low and high end bracket the measured number.
By their numbers in this assay, from the lowest: compounds 2, 3, 4 and 1 (each within the scatter of the next, the first and the last beyond it).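

In this assay, going by these compounds alone, compound 4 gives the first step that removes this one methyl alone, and hydrogen in its place leaves the result within the scatter (a 1.4-fold higher number from compound 3 to compound 4 (0.13 log units; within the scatter)). Compound 4 also cannot be separated from either 4-substituted analogue (a 1.7-fold higher number from compound 2 to compound 4 (0.22 log units; within the scatter); a 1.7-fold lower number from compound 1 to compound 4 (0.24 log units; within the scatter)), even though the step between those two analogues is printed as beyond the scatter. The data offer no measured basis for explaining this outcome.

The compounds shown leave open whether the remaining methyl of the 2-methylphenyl group can also be replaced by hydrogen without a step beyond the scatter. They also leave open how an amine or a carboxylic acid on this ring would read in this assay.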